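Aryl swap at the oxazole of the piperidine-amide series

The source may hold more compounds than are shown below. What is called first, only, known or untested is meant among the compounds shown, and "the series" means these compounds.

Compound 2 `Cc1oc(-c2ccc(Cl)c(Cl)c2)nc1CN1CCC(C(=O)NCCCN2C[C@H](C)C[C@H](C)C2)CC1` in an ADME assay on microsomes from liver (Rattus norvegicus) for metabolic stability, read by LC-MS, using NADPH, at 37 degrees C (a lower number here means that the compound disappears faster, a higher number that the compound lasts longer), reaches only the assay limit > 0.5 h, and that limit of > 0.5 h in this assay, at which 1 of the 3 values shown sits, is the upper edge of the numbers seen here. Among the compounds with values here, compound 1 `CC[C@@H]1C[C@H](CC)CN(CCCNC(=O)C2CCN(Cc3nc(-c4ccccc4C)oc3C)CC2)C1` gives 0.0917 h in this assay, and compound 3 `Cc1ccccc1-c1nc(CN2CCC(C(=O)NCCCN3CCCC(C(C)C)C3)CC2)c(C)o1` gives 0.323 h; the one measured step, a 3.5-fold higher number from compound 1 to compound 3 (0.55 log units; beyond the scatter), concerns the amine end of the chain, not the aryl group. Compound 4 `COc1cccc(OC)c1-c1nc(CN2CCC(C(=O)NCCCN3C[C@H](C)C[C@H](C)C3)CC2)c(C)o1` differs from compound 2 by 2,6-dimethoxyphenyl in place of 3,4-dichlorophenyl on an aromatic carbon. Within the data shown here, no measured step touches this aryl position, so no direction beyond the scatter is established. The expected change is an at least 1.4-fold lower number from compound 2 to compound 4 (0.15 log units; that floor lies within the scatter), an estimate only. Compound 4 is estimated at 0.35 h in this assay, within 0.12 h to 1 h.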

Compound 4, half-life: 0.2 h
Estimate against measurement, compound 4: 1.8-fold (0.24 log units) above; measured number inside the range.
By their numbers in this assay, from the lowest: compound 1; then compounds 4 and 3 (each within the scatter of the next). At a limit, above all of these: compound 2.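

In this assay, 2,6-dimethoxyphenyl in place of 3,4-dichlorophenyl gives an at least 2.5-fold lower number from compound 2 to compound 4 (0.39 log units; beyond the scatter), the first step read at this aryl position, with the amine end unchanged. This shows that the aryl group alone can shift the half-life beyond the scatter. Compound 2 gives a limit, not a number: the limit of > 0.5 h in this assay, at which 1 of the 4 values shown sits.

Still open, on these data alone, is whether the step follows the entering methoxy groups or the leaving chlorines. An unsubstituted phenyl or a pyridine ring at this position would help separate the two.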